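Adding a Methylpiperazine to the Cyclohexylamino Analogue

A few compounds are considered here, and "the series" means these few. Any claim that something is new, unique, unknown or untested is made for them only; others in the source may bear on it.

Going by the values given here, compound 3 `N=C(Nc1ccccc1)c1cc2c(-c3ccccc3)n[nH]c2c(NC2CCCCC2)n1` gives 1710 nM in a functional assay on MDA-MB-231 cells (Homo sapiens) for cytotoxicity, read by MTT assay, with a stated time of 72 h (on this read-out lower numbers stand for stronger inhibition and higher numbers for weaker inhibition), the lowest of the three numbers measured so far. Compound 2 `COc1cc(Nc2nc(C(=N)Nc3ccccc3)cc3c(-c4ccccc4)n[nH]c23)cc(OC)c1OC` gives 4500 nM, and compound 1 `COc1cc(Nc2nc(C(=N)Nc3ccc(N4CCN(C)CC4)cc3)cc3c(-c4ccccc4)n[nH]c23)cc(OC)c1OC` gives 4600 nM. Compound 4 `CN1CCN(c2ccc(NC(=N)c3cc4c(-c5ccccc5)n[nH]c4c(NC4CCCCC4)n3)cc2)CC1` differs from compound 3 by 4-methylpiperazin-1-yl in place of hydrogen on an aromatic carbon. The same change has already been seen in reverse on a closely related pair: a 1.0-fold lower number from compound 1 to compound 2 (0.01 log units; within the scatter), a step that stayed within the scatter. The other step, a 2.6-fold lower number from compound 2 to compound 3 (0.42 log units; beyond the scatter), concerns a different part of the molecule and does not bear directly on this change. The step is therefore expected to stay within the scatter, a 1.0-fold lower number from compound 3 to compound 4 (0.00 log units; within the scatter). Compound 4 is estimated at 1700 nM, with a range from 850 nM to 3400 nM.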

Compound 4, half-maximal inhibitory concentration: 1500 nM
Estimate against measurement, compound 4: 1.1-fold (0.05 log units) above; the measured number falls inside the stated range.
By their numbers in this assay, from the lowest: compounds 4 and 3 (each within the scatter of the next); then compounds 2 and 1 (each within the scatter of the next).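

In this assay, 4-methylpiperazin-1-yl on the aromatic carbon now gives a 1.1-fold lower number from compound 3 to compound 4 (0.06 log units; within the scatter), so hydrogen and this group also read alike on a second core, the one carrying cyclohexyl on the nitrogen: the same change on two cores in this assay, a 1.0-fold lower number (0.01 log units; within the scatter) from compound 1 to compound 2 and a 1.1-fold higher number (0.06 log units; within the scatter) from compound 4 to compound 3, 1.2-fold (0.07 log units) apart, within the scatter of two such steps. The exchange of 3,4,5-trimethoxyphenyl for cyclohexyl also holds with 4-methylpiperazin-1-yl present, at a 3.1-fold lower number from compound 1 to compound 4 (0.49 log units; beyond the scatter), so across these four compounds the two places read independently: the same change on two cores in this assay, a 2.6-fold lower number (0.42 log units; beyond the scatter) from compound 2 to compound 3 and a 3.1-fold lower number (0.49 log units; beyond the scatter) from compound 1 to compound 4, 1.2-fold (0.07 log units) apart, within the scatter of two such steps. The compounds shown leave open whether a carboxylic acid or a dimethylamino group on this aromatic carbon would also read like hydrogen.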